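A few compounds are considered here, and "the series" means these few. Any claim that something is new, unique, unknown or untested is made for them only; others in the source may bear on it.

The three measured compounds, with their numbers from a functional assay on SK-MEL-28 cells (Homo sapiens) for cytotoxicity, read by MTT assay; on this read-out higher numbers stand for weaker inhibition and lower numbers for stronger inhibition:

Compound 1 `O=C(NCCNc1nccc(-c2c(-c3cccc(F)c3)nc3sccn23)n1)c1c(F)cccc1F` gives 11400 nM.
Compound 2 `O=S(=O)(NCCNc1nccc(-c2c(-c3cccc(F)c3)nc3sccn23)n1)c1ccc(F)cc1` gives 9450 nM.
Compound 3 `O=C(NCCNc1nccc(-c2c(-c3cccc(F)c3)nc3sccn23)n1)c1ccc(Cl)cc1` gives 8160 nM.

Compound 3 has the lowest of the three numbers in this assay, but the step of a 1.4-fold lower number from compound 1 to compound 3 (0.15 log units; within the scatter) and the step of a 1.2-fold lower number from compound 2 to compound 3 (0.06 log units; within the scatter) are both within the scatter, so nothing separates it from the other two. Compound 4 `O=S(=O)(NCCNc1nccc(-c2c(-c3cccc(F)c3)nc3sccn23)n1)c1ccccc1` differs from compound 3 in one place: phenylsulfonyl in place of (4-chlorophenyl)carbonyl on an amine nitrogen. Among the compounds with values here, two measured steps bear on this change. An exchange of a carbonyl for a sulfonyl on the same amine nitrogen was seen in a 1.2-fold lower number from compound 1 to compound 2 (0.08 log units; within the scatter), and the reverse exchange in a 1.2-fold lower number from compound 2 to compound 3 (0.06 log units; within the scatter); both stayed within the scatter. The expected step is therefore a 1.1-fold higher number from compound 3 to compound 4 (0.04 log units; within the scatter), which amounts to none beyond the scatter. The estimate for compound 4 in this assay is 9000 nM, with a range from 4500 nM to 18000 nM.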

Compound 4, half-maximal inhibitory concentration: 19000 nM
Estimate against measurement, compound 4: 2.1-fold (0.32 log units) below; the whole stated range lies below it.
By their numbers in this assay, from the lowest: compounds 3, 2, 1 and 4 (each within the scatter of the next, the first and the last beyond it).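

In this assay, within the data shown here, the exchange on the amine nitrogen now passes the scatter for the first time, with a 2.3-fold higher number from compound 3 to compound 4 (0.37 log units; beyond the scatter), though only modestly, when phenylsulfonyl takes the place of (4-chlorophenyl)carbonyl. The sulfonyl alone does not account for this: a 2.0-fold higher number from compound 2 to compound 4 (0.30 log units; within the scatter), with hydrogen in place of fluoro on an aromatic carbon, and a 1.7-fold higher number from compound 1 to compound 4 (0.22 log units; within the scatter), with phenylsulfonyl in place of (2,6-difluorophenyl)carbonyl, both stay within the scatter, so compound 4 stands apart only from compound 3. Nothing at hand explains this step.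

The step to compound 4 changes the carbonyl and removes the chloro together, so the two cannot be told apart here; a (4-chlorophenyl)sulfonyl or a plain phenylcarbonyl group on the same nitrogen would separate them. From the compounds shown here alone, how an amine or a carboxylic acid on that aromatic ring would behave also remains open.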